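Benzyloxycarbonyl in place of phenyl on the ring nitrogen

The source may hold more compounds than are shown below. What is called first, only, known or untested is meant among the compounds shown, and "the series" means these compounds.

Compound 3 `COc1ccc(S(=O)(=O)NCCCN2CCN(c3ccccc3)CC2)cc1` stands at the floor of an assay on CHO cells for displacement of a labelled ligand from 5-hydroxytryptamine receptor 7 (Homo sapiens); on this read-out higher numbers stand for weaker inhibition and lower numbers for stronger inhibition: in this assay compound 3 gives > 10000 nM, which is a limit and not a number, at which (the limit of > 10000 nM in this assay, at which 1 of the 3 values shown sits). Compound 1 `COc1ccc(S(=O)(=O)NCCCN2CCN(c3ccc(C(F)(F)F)cc3)CC2)cc1` gives 384 nM in this assay, and compound 2 `COc1ccc(N2CCN(CCCNS(=O)(=O)c3ccc(OC)cc3)CC2)cc1` gives 9310 nM. The measured steps run an at least 26-fold higher number from compound 1 to compound 3 (1.41 log units; beyond the scatter) and a 24-fold higher number from compound 1 to compound 2 (1.38 log units; beyond the scatter), while the step of an at least 1.0-fold higher number from compound 2 to compound 3 (0.03 log units; that floor lies within the scatter) cannot be sized beyond its floor. Compound 4 `COc1ccc(S(=O)(=O)NCCCN2CCN(C(=O)OCc3ccccc3)CC2)cc1` replaces the aryl group on the ring nitrogen of compound 3 with a carbamate: benzyloxycarbonyl in place of phenyl on an amine nitrogen in a ring. Going by the values given here, no measured step alters the group on the ring nitrogen itself; the known steps only vary the substituent on that aryl ring, and both end at compound 3 on the limit. Among the compounds with values here, the change to compound 4 thus has no direct precedent here, and the expectation rests on compound 3 alone. The value > 10000 nM of compound 3 is a limit. Compound 4 is expected to stay near that floor, a step of a number no higher from compound 3 to compound 4 (the limit leaves the size open). Compound 4 is estimated at 10000 nM in this assay, with a range from 3000 nM to 30000 nM, and a further limit reading is likely.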

Compound 4, half-maximal inhibitory concentration: > 10000 nM
Compound 4 gave a limit, no number; the forecaster's own chance of this, stated with the estimate: 65%; the middle value lies on the limit itself.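

In this assay, going by these compounds alone, compound 4 gives > 10000 nM, which is a limit and not a number, and this is the first change here to the group on the ring nitrogen itself rather than to a substituent on its aryl ring. Replacing 4-(trifluoromethyl)phenyl with benzyloxycarbonyl on that nitrogen gives an at least 26-fold higher number from compound 1 to compound 4 (1.41 log units; beyond the scatter), while replacing 4-methoxyphenyl with benzyloxycarbonyl gives an at least 1.0-fold higher number from compound 2 to compound 4 (0.03 log units; that floor lies within the scatter). The step from compound 3 to compound 4 cannot be read, and the limit now takes in both phenyl and benzyloxycarbonyl on the ring nitrogen: the limit of > 10000 nM in this assay, at which 2 of the 4 values shown sit.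

Going by these compounds, it remains open whether a trifluoromethyl group on the aromatic ring of benzyloxycarbonyl would bring the carbamate series back to a measurable value, as that group does on the phenyl ring in compound 1. The compounds shown also do not tell how a plain benzyl group on the ring nitrogen, without the carbonyl, or a nitrile in place of trifluoromethyl on the aryl ring, would read in this assay.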